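This account rests on a few compounds, and the source may have more. Where it says the series, first, only, none or still open, it means among the compounds named here.

Of the compounds shown here, three with a shared core have been measured so far. Compound 1 `CCCCN(CC)c1nc(C)nc2c1nnn2-c1c(C)cc(C)cc1C` gives 27.5 nM in an in vitro assay on 293-EBNA cells for binding affinity to corticotropin-releasing factor receptor 1 (Homo sapiens); a lower number here means a stronger inhibitor, a higher number a weaker inhibitor. Going by the values given here, compound 2 `CCCC(CCC)Nc1nc(C)nc2c1nnn2-c1c(C)cc(C)cc1C` gives 4 nM in this assay, and the step of a 6.9-fold lower number from compound 1 to compound 2 (0.84 log units; beyond the scatter) is the only one-place change measured. Compound 3 `COCC(COC)Nc1nc(C)nc2c1nnn2-c1ccc(C(C)C)cc1Br` gives 10.3 nM in this assay; its number is the second highest of the three, lying between compound 1 and compound 2 and beyond the scatter of each.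

Compound 4 `CCCC(CN(C)C)Nc1nc(C)nc2c1nnn2-c1ccc(C(C)C)cc1Br` differs from compound 3 in a group of 8 heavy atoms (7 carbon, 1 nitrogen; no ring) in place of a group of 7 heavy atoms (5 carbon, 2 oxygen; no ring), on a nitrogen on an aromatic ring. Among the compounds with values here, the only measured step that bears on this is the one from compound 1 to compound 2, which also reworked the substituent on that nitrogen and produced a 6.9-fold lower number from compound 1 to compound 2 (0.84 log units; beyond the scatter), a modest gain on branching out the chain. Within the data shown here, no measured pair exchanges an oxygen-bearing chain for a nitrogen-bearing one, so the direction for compound 4 is not fixed by the data; a small improvement, or no change beyond the scatter, seems the more likely outcome. Compound 4 is therefore expected to give about 7 nM in this assay, within a range of 2 nM to 25 nM. The expected step is a 1.5-fold lower number from compound 3 to compound 4 (0.17 log units; within the scatter).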

Compound 4, inhibition constant: 38.7 nM
Compound 4: the middle estimate sits 5.5-fold (0.74 log units) below what was measured, outside the stated range (above it).
By their numbers in this assay, from the lowest: compound 2; then compound 3; then compounds 1 and 4 (each within the scatter of the next).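

Replacing the 2-methoxy-1-(methoxymethyl)ethyl group with the group of 8 heavy atoms that holds 1 nitrogen gives a 3.8-fold higher number from compound 3 to compound 4 (0.57 log units; beyond the scatter) in this assay, a loss beyond the scatter. Going by these compounds alone, the only earlier step on this nitrogen, a 6.9-fold lower number from compound 1 to compound 2 (0.84 log units; beyond the scatter), was a gain, so the substituent here is now seen to move the number in both directions, and the two branched groups of compound 3 and compound 4 are not interchangeable. Nothing in the available evidence accounts for this loss.

The two groups differ in more than one feature, so the compounds shown do not separate the effect of the dimethylamino group from that of the propyl arm or of the missing methoxy groups; a chain carrying one methoxymethyl arm and one propyl arm, or a chain ending in a primary amine, would bear on that. It also remains open whether the 1-propylbutyl group, which gives the lowest number among these compounds, keeps its advantage on the aromatic ring carried by compound 3 and compound 4.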